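Series notes: 1H-imidazol-1-yl in place of methylsulfanyl

The source may hold more compounds than are shown below. What is called first, only, known or untested is meant among the compounds shown, and "the series" means these compounds.

Measured in a functional assay on the whole organism (trachea) for inhibition, with Cavia porcellus as the target; on this read-out lower numbers stand for an effect already at smaller amounts and higher numbers for an effect only at larger amounts of compound
- compound 1 `COc1ccccc1OCC1SCCN1C(=O)CSC` gives 21 mg/kg
- compound 2 `CSCC(=O)N1CCSC1COc1ccccc1O` gives 28 mg/kg

Compound 2 at 28 mg/kg stands within the scatter of compound 1 (21 mg/kg) and so offers no separation from it. The next case is compound 3 `O=C(Cn1ccnc1)N1CCSC1COc1ccccc1O`, with the change 1H-imidazol-1-yl in place of methylsulfanyl on a saturated chain carbon bound to a carbonyl carbon on a saturated chain carbon bound to a carbonyl carbon. Within the data shown here, the only measured step, a 1.3-fold higher number from compound 1 to compound 2 (0.12 log units; within the scatter), is hydrogen in place of methyl on an oxygen on an aromatic ring. It lies at another place and gives no measure of this change. Among the measured compounds shown here, no measured step covers the incoming group, so no direction can be expected in this assay and the range must stay wide. Expected is a 1.1-fold higher number from compound 2 to compound 3 (0.03 log units; within the scatter) and no step beyond the scatter. The estimated value for compound 3 is 30 mg/kg within an expected range (10 mg/kg to 90 mg/kg).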

Compound 3, dose for half-maximal effect: 27 mg/kg
The estimate for compound 3 lay 1.1-fold (0.05 log units) above the measured number; low and high end bracket the measured number.
By their numbers in this assay, from the lowest: compounds 1, 3 and 2 (each within the scatter of the next).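

In this assay, among these compounds, the saturated chain carbon bound to a carbonyl carbon takes 1H-imidazol-1-yl in place of methylsulfanyl with a 1.0-fold lower number from compound 2 to compound 3 (0.02 log units; within the scatter), which gives this position a first reading of its own, apart from the earlier step on the oxygen on the aromatic ring. A five-membered aromatic ring with 2 hetero atoms stands here where no ring stood, and the read-out does not separate compound 2 from compound 3. Nothing at hand gives a reason for this result.

Going by these compounds, only compound 2 and compound 3 speak to this position, so it remains open whether another group here, such as a dimethylamino group, a carboxylic acid or a longer chain, would give a step beyond the scatter. Also open, on these data alone, is how methyl in place of hydrogen on the oxygen on the aromatic ring would read with 1H-imidazol-1-yl at this place.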